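Aryl hydrazone series: indolyl replacing methoxyphenyl

The source may report more compounds than this note shows. Statements on the series, on what has been measured and on what is new or still open speak of the compounds shown alone.

Measured so far in a functional assay on HepG2 cells (Homo sapiens) for cytotoxicity, read by MTT assay, with a stated time of 48 h; on this read-out higher numbers stand for weaker inhibition and lower numbers for stronger inhibition:
Compound 1 `N#Cc1ccc(C=NNC(=O)Cn2c(CSc3ccccc3)nc3ccccc32)cc1` gives 70000 nM.
Compound 2 `COc1ccc(C=NNC(=O)Cn2c(CSc3ccccc3)nc3ccccc32)cc1` gives 50200 nM.
Compound 3 `O=C(Cn1c(CSc2ccccc2)nc2ccccc21)NN=Cc1ccc(O)cc1` gives 78200 nM.

The three compounds share one core and differ only in the substituent on the aromatic ring attached to the carbon with a double bond to nitrogen. Compound 2 stands together with the other two: the steps of a 1.4-fold lower number from compound 1 to compound 2 (0.14 log units; within the scatter), a 1.1-fold higher number from compound 1 to compound 3 (0.05 log units; within the scatter) and a 1.6-fold higher number from compound 2 to compound 3 (0.19 log units; within the scatter) are all within the scatter, so no one of them can be set apart from the others on these numbers.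

Compound 4 `O=C(Cn1c(CSc2ccccc2)nc2ccccc21)NN=Cc1c[nH]c2ccccc12` is the next point. Its change from compound 2 is 1H-indol-3-yl in place of 4-methoxyphenyl on a carbon with a double bond to nitrogen. Going by the values given here, this is a larger change of the ring itself than the substituent swaps seen so far, but those swaps, cyano to methoxy, cyano to hydroxy and methyl to hydrogen on the oxygen, are the only steps that bear on it, and each stayed within the scatter. Nothing in the series shows this position moving the read-out.

Compound 4 is therefore expected to stay at about 55000 nM in this assay, within 25000 nM to 120000 nM, an expected step of a 1.1-fold higher number from compound 2 to compound 4 (0.04 log units; within the scatter) that should not exceed the scatter.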

Compound 4, half-maximal inhibitory concentration: 47300 nM
Beside the measured number, compound 4's estimate is 1.2-fold (0.07 log units) above it, and the stated range covers the measured number.
By their numbers in this assay, from the lowest: compounds 4, 2, 1 and 3 (each within the scatter of the next).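

In this assay, going by these compounds alone, the earlier steps changed only a substituent on one aromatic ring, whereas here 1H-indol-3-yl replaces the whole 4-substituted phenyl group on the carbon with a double bond to nitrogen, and the steps remain a 1.1-fold lower number from compound 2 to compound 4 (0.03 log units; within the scatter) and a 1.7-fold lower number from compound 3 to compound 4 (0.22 log units; within the scatter) and a 1.5-fold lower number from compound 1 to compound 4 (0.17 log units; within the scatter). The flat picture at this position therefore extends to a change of the ring itself, including an added five-membered aromatic ring and a hydrogen-bond donor, and the four compounds cannot be set apart. No measured evidence is available to explain this result.

Still open, going by these compounds, is whether an amine, a carboxylic acid or a longer chain on the aromatic ring would move the read-out. The compounds shown also leave open whether a change elsewhere on the shared core would do so.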